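Swapping a Five-Membered Ring on the Aromatic Carbon

The source may hold more compounds than are shown below. What is called first, only, known or untested is meant among the compounds shown, and "the series" means these compounds.

Compound 1 `CN(c1cccc(NC(=O)CN2N=C(C3CCCCC3)c3ccccc3N(CC(=O)C(C)(C)C)C2=O)c1)c1nn[nH]n1`: 4.68 nM
Compound 2 `CC(C)(C)C(=O)CN1C(=O)N(CC(=O)Nc2cccc(-c3nc(=O)o[nH]3)c2)N=C(C2CCCCC2)c2ccccc21`: 4.47 nM

In a functional assay on gastric mucosa for displacement of a labelled ligand from Gastrin/cholecystokinin type B receptor (Canis lupus familiaris), read by CCK-8 assay (a higher number here means a weaker inhibitor, a lower number a stronger inhibitor), compound 2 gives 4.47 nM, the lowest of the two numbers, while compound 1 gives 4.68 nM; the step of a 1.0-fold lower number from compound 1 to compound 2 (0.02 log units; within the scatter) keeps the pair within the scatter. Compound 3 `CC(C)(C)C(=O)CN1C(=O)N(CC(=O)Nc2cccc(-c3nn[nH]n3)c2)N=C(C2CCCCC2)c2ccccc21` differs from compound 2 by a group of 5 heavy atoms (1 carbon, 4 nitrogen; one five-membered aromatic ring with 4 hetero atoms) in place of a group of 6 heavy atoms (2 carbon, 2 nitrogen, 2 oxygen; one five-membered aromatic ring with 3 hetero atoms), on an aromatic carbon. For the measured compounds named here, the only measured step at this position is a 1.0-fold lower number from compound 1 to compound 2 (0.02 log units; within the scatter), and it did not move the number beyond the scatter. For the new swap, likewise no step beyond the scatter is expected in this assay. Compound 3 is therefore estimated at 4.5 nM, with a range from 1.5 nM to 14 nM. The expected step is a 1.0-fold higher number from compound 2 to compound 3 (0.00 log units; within the scatter).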

Compound 3, inhibition constant: 3.16 nM
Beside the measured number, compound 3's estimate is 1.4-fold (0.15 log units) above it; the measured number falls inside the stated range.
By their numbers in this assay, from the lowest: compounds 3, 2 and 1 (each within the scatter of the next).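

In this assay, the 2H-tetrazol-5-yl group placed directly on the aromatic carbon stays within the scatter of the other five-membered ring (a 1.4-fold lower number from compound 2 to compound 3 (0.15 log units; within the scatter)). It also stays within the scatter of (2H-tetrazol-5-yl)(methyl)amino (a 1.5-fold lower number from compound 1 to compound 3 (0.17 log units; within the scatter)), so across these three compounds neither the ring swap nor the nitrogen-and-methyl link moves the number beyond the scatter. No measurement here explains this flat result. From the compounds shown here alone, whether a carboxylic acid or a simple amine at this place would keep the number in the same range remains open.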